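From Dichloro to Difluoro: a Small Halogen Swap

A few compounds are considered here, and "the series" means these few. Any claim that something is new, unique, unknown or untested is made for them only; others in the source may bear on it.

Measured compounds:
compound 1 `COc1ccc(-c2cc(/C=C/C(=O)c3ccc(OC)c(OC)c3)[nH]n2)cc1`: -100%
compound 2 `COc1cc(-c2cc(/C=C/C(=O)c3ccc(Cl)c(Cl)c3)[nH]n2)cc(OC)c1OC`: -32%
compound 3 `COc1ccc(-c2cc(/C=C/C(=O)c3ccc(N)cc3)[nH]n2)cc1`: -15%

These three compounds were tested in a functional assay on HCT-116 cells (Homo sapiens) for cytotoxicity, read by sulforhodamine B assay, with a stated time of 48 h, tested at 100 uM; a lower number here means a stronger effect, a higher number a weaker effect of the compound at the concentration tested. Among the three numbers, compound 2 stands second highest. Its nearest neighbour is compound 3, whose number is higher by a gap beyond the usual scatter, and its furthest is compound 1, whose number lies far lower, also beyond the scatter. Compound 4 `COc1cc(-c2cc(/C=C/C(=O)c3ccc(F)c(F)c3)[nH]n2)cc(OC)c1OC` has not yet been measured. It differs from compound 2 in one place: 3,4-difluorophenyl in place of 3,4-dichlorophenyl on a carbonyl carbon. Among the compounds with values here, no pair of measured compounds differs by just such a change, so no measured step guides the expectation directly. The step from compound 2 to compound 4 is expected to be small, possibly not beyond the scatter, with a slight lean toward a weaker effect. Compound 4 is therefore estimated at -20% in this assay, within a range from -50% to 5%. That estimate means an expected step of a number 12 percentage points higher from compound 2 to compound 4 (beyond the scatter).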

Compound 4, a percentage reported as activity, at one concentration (the size of the read-out at that concentration, not a potency): -52%
Estimate against measurement, compound 4: 32 percentage points above, and the stated range ends above it.
By their numbers in this assay, from the lowest: compound 1; then compound 4; then compound 2; then compound 3.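

In this assay, replacing 3,4-dichlorophenyl with 3,4-difluorophenyl on a carbonyl carbon gives a number 20 percentage points lower from compound 2 to compound 4 (beyond the scatter), so this position responds to a change of halogen alone, and here fluorine goes with the stronger effect. The two groups match in heavy-atom count, in their aromatic ring and in having no hydrogen-bond donors or acceptors, so these counted features do not separate them, and chlorine against fluorine is the only difference. No measurement at hand shows what lies behind the step. This single pair leaves open how a 3,4-dibromophenyl group, a phenyl ring with one fluorine or a pyridine ring would fare at this position. It also leaves open whether the same halogen swap would move the number in the same direction on the core of compound 3.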